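Caco-2 permeability across amide variants of one core

The source may hold more compounds than are shown below. What is called first, only, known or untested is meant among the compounds shown, and "the series" means these compounds.

The series shares one core on which the group at the carbonyl carbon is exchanged. Compound 1 `Cn1cncc1CN1CC(N(CC2CCN(C(=O)c3ccc(Cl)cc3)CC2)S(=O)(=O)c2ccccn2)Cc2cc(C#N)ccc21` gives 0.5 10^-6 cm/s in an ADME assay on Caco-2 cells (Homo sapiens) for permeability, in the apical to basolateral direction; a higher number here means that the compound crosses the layer faster, a lower number that the compound crosses the layer more slowly. Compound 2 `Cn1cncc1CN1CC(N(CC2CCN(C(=O)CNC(=O)OC(C)(C)C)CC2)S(=O)(=O)c2ccccn2)Cc2cc(C#N)ccc21` gives 0.5 10^-6 cm/s in this assay, and no change at the digits printed from compound 1 to compound 2 (within the scatter). Compound 3 `Cn1cncc1CN1CC(N(CC2CCN(C(=O)Nc3ccc(Br)cc3)CC2)S(=O)(=O)c2ccccn2)Cc2cc(C#N)ccc21` gives 0.6 10^-6 cm/s in this assay; the steps of a 1.2-fold higher number from compound 1 to compound 3 (0.08 log units; within the scatter) and a 1.2-fold higher number from compound 2 to compound 3 (0.08 log units; within the scatter) are both within the scatter. The number for compound 3 is the highest of the three, yet its nearest neighbour compound 1 and its furthest neighbour compound 2 both sit within the scatter of it, so no ordering among the three can be read from these values.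

Compound 4 `Cn1cncc1CN1CC(N(CC2CCN(C(=O)c3ccco3)CC2)S(=O)(=O)c2ccccn2)Cc2cc(C#N)ccc21` differs from compound 3 in one place: furan-2-yl in place of (4-bromophenyl)amino on a carbonyl carbon. All three exchanges at this carbonyl carbon that have been measured, no change at the digits printed from compound 1 to compound 2 (within the scatter), a 1.2-fold higher number from compound 1 to compound 3 (0.08 log units; within the scatter) and a 1.2-fold higher number from compound 2 to compound 3 (0.08 log units; within the scatter), remained within the scatter. With nothing among them moving this assay beyond its noise, the exchange to furan-2-yl is expected to behave alike, and no change at the digits printed from compound 3 to compound 4 (within the scatter) is the estimated step, meaning no change beyond the scatter. Compound 4 is therefore expected at 0.6 10^-6 cm/s in this assay, with a range from 0.3 10^-6 cm/s to 1.2 10^-6 cm/s.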

Compound 4, apparent permeability: 0.5 10^-6 cm/s
Compound 4: the middle estimate sits 1.2-fold (0.08 log units) above what was measured; the measured number falls inside the stated range.
By their numbers in this assay, from the lowest: compounds 1, 2, 4 and 3 (each within the scatter of the next).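

Exchanging (4-bromophenyl)amino for furan-2-yl on this carbonyl carbon replaces 8 heavy atoms with 5 and 1 hydrogen-bond donor with 1 hydrogen-bond acceptor, yet this assay shows only a 1.2-fold lower number from compound 3 to compound 4 (0.08 log units; within the scatter). The comparisons with the other two groups read no change at the digits printed from compound 2 to compound 4 (within the scatter) and no change at the digits printed from compound 1 to compound 4 (within the scatter), so a five-membered aromatic ring with 1 hetero atom also cannot be separated from the earlier groups at this position. No accompanying measurement bears on why the four numbers stay together.

Still open, on these data alone, is whether a primary amine, a carboxylic acid or a longer chain on this carbonyl carbon would carry this assay beyond the scatter. As far as these compounds go, because all four compounds share the core, the effect of a change elsewhere on it also remains open.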